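This account rests on a few compounds, and the source may have more. Where it says the series, first, only, none or still open, it means among the compounds named here.

Compound 1 `CN(C(=O)c1ccccc1)c1ccc2[nH]c(-c3n[nH]c4ccccc34)cc2n1` is the weaker of the two measured compounds in a functional assay on HL-60 cells (Homo sapiens) for antiproliferative activity, read by MTT assay, with a stated time of 72 h (on this read-out higher numbers stand for weaker inhibition and lower numbers for stronger inhibition), where compound 1 gives 4850 nM. The other measured compound, compound 2 `COc1cccc(C(=O)N(C)c2ccc3[nH]c(-c4n[nH]c5ccccc45)cc3n2)c1`, differs from it at a single aromatic carbon, and in this assay compound 2 gives 1420 nM, so that one change produced a 3.4-fold lower number from compound 1 to compound 2 (0.53 log units; beyond the scatter). Compound 3 `CN(C(=O)c1ccccc1)c1ccc2[nH]c(-c3n[nH]c4cc(C#N)ccc34)cc2n1` departs from compound 1 at a different aromatic carbon, on the fused two-ring part of the molecule: cyano in place of hydrogen on an aromatic carbon. For the measured compounds named here, the only measured step, from compound 1 to compound 2, concerns a methoxy group at another site, so it gives no direct guide to a cyano group here. Nothing measured in this set speaks to a change at this position. The safest expectation is therefore that compound 3 stays close to compound 1, and the step is expected to be a 1.4-fold lower number from compound 1 to compound 3 (0.14 log units; within the scatter), a shift that may well fall within the usual scatter. On that basis compound 3 is estimated at 3500 nM, with a plausible range from 1000 nM to 12000 nM.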

Compound 3, half-maximal inhibitory concentration: 6430 nM
For compound 3 the middle estimate is 1.8-fold (0.26 log units) below the measured one; measured number inside the range.
By their numbers in this assay, from the lowest: compound 2; then compounds 1 and 3 (each within the scatter of the next).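

In this assay, the step for cyano in place of hydrogen on this aromatic carbon of the fused system of two rings is a 1.3-fold higher number from compound 1 to compound 3 (0.12 log units; within the scatter), so compound 3 and compound 1 cannot be told apart. For the compounds shown here, this is the first reading at this position, and it shows that the position can carry a cyano group, with its 2 heavy atoms, without a shift beyond the usual scatter, unlike the methoxy change at the other site, which gave a 3.4-fold lower number from compound 1 to compound 2 (0.53 log units; beyond the scatter). No independent measurement is available to explain this result.

On these data alone, a single group at a single position says little about how far this tolerance extends, so it remains open whether an amine, a carboxylic acid or a longer chain on the same carbon would also leave the number within the scatter of compound 1, or would move it in either direction. As far as these compounds go, it is also open whether the cyano group at this position and the methoxy group of compound 2, placed together in one molecule, would give a number lower than that of compound 2 alone.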